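Shortening the Alkoxy Chain: Butoxy to Isopropoxy

This account rests on a few compounds, and the source may have more. Where it says the series, first, only, none or still open, it means among the compounds named here.

Compound 1 `Oc1ccc2nc(-c3ccccc3)cc(O)c2c1`: 0.41 ug/mL in a functional assay on KB cells (Homo sapiens) for cytotoxicity; on this read-out lower numbers stand for an effect already at smaller amounts and higher numbers for an effect only at larger amounts of compound.
Compound 2 `Oc1cc(-c2ccccc2)nc2cc(F)ccc12`: < 0.1 ug/mL, which is a limit of the assay and not a number.
Compound 3 `CCCCOc1cc(-c2ccccc2)nc2ccccc12`: 3.8 ug/mL.

Of the two numbers, compound 3 carries the highest; its nearest neighbour is compound 1, whose lower number lies beyond the usual scatter. Compound 4 `CC(C)Oc1cc(-c2ccccc2)nc2ccccc12` has not been measured. It differs from compound 3 in one place: isopropyl in place of butyl on an oxygen on an aromatic ring. Going by the values given here, no measured pair separates two such ethers, so the size of this step is unknown. The change is expected to move the read-out little, with a step from a 1.3-fold lower number from compound 3 to compound 4 (0.10 log units; within the scatter) that stays within the scatter. For compound 4 the estimate is 3 ug/mL, with a range from 1 ug/mL to 9 ug/mL.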

Compound 4, half-maximal effective concentration: 4.2 ug/mL
For compound 4 the middle estimate is 1.4-fold (0.15 log units) below the measured one, and the stated range covers the measured number.
By their numbers in this assay, from the lowest: compound 1; then compounds 3 and 4 (each within the scatter of the next). At a limit, below all of these: compound 2.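

In this assay, going by these compounds alone, the first pair of ethers on this oxygen gives a 1.1-fold higher number from compound 3 to compound 4 (0.04 log units; within the scatter), so exchanging butyl for isopropyl at this place does not shift the read-out by more than repeat measurements would. For these two compounds, the exact shape of the chain on the oxygen therefore makes no measurable difference. Nothing shown here bears on why the step is so small.

Going by these compounds, whether this holds further afield stays open: a methyl group or a much longer chain on the oxygen, or an amine in place of the ether, could behave differently.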